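The source may report more compounds than this note shows. Statements on the series, on what has been measured and on what is new or still open speak of the compounds shown alone.

The series shares one core, esterified at the secondary alcohol with acids of increasing size. Compound 1 `CC(=O)O[C@H]1C(=O)OCC1(C)C` gives 33200 nM in an assay on isolated protein for inhibition of fatty acid synthase (Mus musculus), read by spectrophotometry, using NADPH, with stated times of 30 min and 3 min, in the presence of a further agent that is not named here; a higher number here means a weaker inhibitor, a lower number a stronger inhibitor. Compound 2 `CCCC(=O)O[C@H]1C(=O)OCC1(C)C` gives 28200 nM in this assay, and the step of a 1.2-fold lower number from compound 1 to compound 2 (0.07 log units; within the scatter) lies within the scatter. Compound 3 `CC1(C)COC(=O)[C@@H]1OC(=O)c1ccccc1` carries an aromatic ester and gives 23000 nM in this assay; its number is the lowest of the three, but its gaps to compound 2 and to compound 1 both sit within the scatter, so no ordering among the three can be claimed.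

Compound 4 `COc1ccc(C(=O)O[C@H]2C(=O)OCC2(C)C)cc1` differs from compound 3 by methoxy in place of hydrogen on an aromatic carbon. Among the measured compounds shown here, none of the measured steps touches the aromatic ring; the only step, from compound 1 to compound 2, concerns the saturated chain and was itself within the scatter. Nothing in the data therefore points to a change beyond the scatter in this assay for compound 4. Compound 4 is expected to give about 20000 nM, with a plausible range from 8000 nM to 50000 nM. The expected step of a 1.2-fold lower number from compound 3 to compound 4 (0.06 log units; within the scatter) is accordingly estimated to be small.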

Compound 4, half-maximal inhibitory concentration: 13700 nM
Beside the measured number, compound 4's estimate is 1.5-fold (0.16 log units) above it, and the stated range covers the measured number.
By their numbers in this assay, from the lowest: compounds 4, 3, 2 and 1 (each within the scatter of the next, the first and the last beyond it).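

Methoxy in place of hydrogen on an aromatic carbon, para to a large group, gives a 1.7-fold lower number from compound 3 to compound 4 (0.23 log units; within the scatter) in this assay, the first measured step on the aromatic ring. This place therefore accepts a group of 2 heavy atoms with 1 hydrogen-bond acceptor with no loss beyond the scatter, though no gain can be claimed either. No available evidence bears on this result.

The compounds shown leave open whether an amine or a carboxylic acid in place of the methoxy would move the number beyond the scatter, and whether methoxy on another carbon of the ring would behave in the same way. They also leave open whether a longer chain on the saturated ester would differ from compound 2.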